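Aryl imine variation on the benzofuran series

This account rests on a few compounds, and the source may have more. Where it says the series, first, only, none or still open, it means among the compounds named here.

Compound 2 `CCCCc1oc2ccc(/N=C/c3ccc(F)cc3)cc2c1C(=O)c1ccc(OC)cc1` gives 100 ug/mL in a functional assay, with a stated time of 30 min (on this read-out lower numbers stand for stronger inhibition and higher numbers for weaker inhibition), the highest of the two numbers to hand; compound 1 `CCCCc1oc2ccc(/N=C/c3cccc([N+](=O)[O-])c3)cc2c1C(=O)c1ccc(OC)cc1` gives 34.2 ug/mL. Among the measured compounds shown here, the one measured step, a 2.9-fold higher number from compound 1 to compound 2 (0.47 log units; beyond the scatter), concerns a different aryl exchange and bears only loosely on the next one. Compound 3 `CCCCc1oc2ccc(/N=C/c3ccc(OC)cc3OC)cc2c1C(=O)c1ccc(OC)cc1` differs from compound 2 by 2,4-dimethoxyphenyl in place of 4-fluorophenyl on a carbon with a double bond to nitrogen. With a single step for guidance and no prior exchange of this kind, no direction beyond the scatter is expected; the step of a 1.3-fold lower number from compound 2 to compound 3 (0.10 log units; within the scatter) is an estimate near zero. For compound 3 the expected value is 80 ug/mL, with a range from 30 ug/mL to 200 ug/mL.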

Compound 3, half-maximal inhibitory concentration: 20.5 ug/mL
For compound 3 the middle estimate is 3.9-fold (0.59 log units) above the measured one; the measured number lies below the stated range.
By their numbers in this assay, from the lowest: compounds 3 and 1 (each within the scatter of the next); then compound 2.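

Exchanging 4-fluorophenyl for 2,4-dimethoxyphenyl on the carbon with a double bond to nitrogen gives a 4.9-fold lower number from compound 2 to compound 3 (0.69 log units; beyond the scatter) in this assay, a larger step than the one earlier seen at this position. Exchanging 3-nitrophenyl for 2,4-dimethoxyphenyl gives only a 1.7-fold lower number from compound 1 to compound 3 (0.22 log units; within the scatter), so these two aryl groups stay level and 4-fluorophenyl alone stands apart. Nothing at hand explains these differences. On these data alone, it remains open whether one methoxy group would match the pair. Unsubstituted phenyl and a phenyl bearing a dimethylamino group also remain open.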